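Sulfonate series: nitro to dimethylamino on the amide end

This account rests on a few compounds, and the source may have more. Where it says the series, first, only, none or still open, it means among the compounds named here.

Compound 1 `N#Cc1cccc(S(=O)(=O)Oc2ccc(-c3cncn3C3CCN(C(=O)c4ccc([N+](=O)[O-])cc4)CC3)cc2)c1` is the reference; in an assay on THP-1 cells for antagonist activity at P2X purinoceptor 7 (Homo sapiens), read by ELISA, with a stated time of 30 min (on this read-out higher numbers stand for weaker inhibition and lower numbers for stronger inhibition), compound 1 gives 13 nM. Compound 2 `CN(C)c1ccc(C(=O)N2CCC(n3cncc3-c3ccc(OS(=O)(=O)c4cccc(C#N)c4)cc3)CC2)cc1` carries dimethylamino in place of nitro on an aromatic carbon and in this assay compound 2 gives 10 nM; the step is a 1.3-fold lower number from compound 1 to compound 2 (0.11 log units; within the scatter). The core of compound 3 `CNC(=O)c1cccc(S(=O)(=O)Oc2ccc(-c3cncn3C3CCN(C(=O)c4ccc([N+](=O)[O-])cc4)CC3)cc2)c1` differs from that of compound 1 by methylcarbamoyl in place of cyano on an aromatic carbon; in this assay compound 3 gives 26 nM, a step of a 2.0-fold higher number from compound 1 to compound 3 (0.30 log units; within the scatter). Compound 4 `CNC(=O)c1cccc(S(=O)(=O)Oc2ccc(-c3cncn3C3CCN(C(=O)c4ccc(N(C)C)cc4)CC3)cc2)c1` is not yet measured and differs from compound 3 by dimethylamino in place of nitro on an aromatic carbon. The change sits at the same place, on an aromatic carbon of a six-membered aromatic ring of carbon only, para to a large group, so it is the same change as between compound 1 and compound 2, now made on the core of compound 3. On that single precedent a step of a 1.3-fold lower number from compound 3 to compound 4 (0.11 log units; within the scatter) is expected, resting on the earlier step of a 1.3-fold lower number from compound 1 to compound 2 (0.11 log units; within the scatter). Compound 4 is therefore estimated at 20 nM in this assay, with a range from 9 nM to 45 nM.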

Compound 4, half-maximal inhibitory concentration: 22 nM
The estimate for compound 4 lay 1.1-fold (0.04 log units) below the measured number, and the stated range covers the measured number.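

In this assay, dimethylamino in place of nitro gives a 1.2-fold lower number from compound 3 to compound 4 (0.07 log units; within the scatter), so the change carries to the second core without a visible difference: the same change on two cores in this assay, a 1.3-fold lower number (0.11 log units; within the scatter) from compound 1 to compound 2 and a 1.2-fold lower number (0.07 log units; within the scatter) from compound 3 to compound 4, 1.1-fold (0.04 log units) apart, within the scatter of two such steps
Methylcarbamoyl in place of cyano gives a 2.2-fold higher number from compound 2 to compound 4 (0.34 log units; beyond the scatter), which also agrees with its earlier step: the same change on two cores in this assay, a 2.0-fold higher number (0.30 log units; within the scatter) from compound 1 to compound 3 and a 2.2-fold higher number (0.34 log units; beyond the scatter) from compound 2 to compound 4, 1.1-fold (0.04 log units) apart, within the scatter of two such steps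
Within these four compounds the two changes therefore combine without interfering, but each comparison rests on a single pair of steps in one assay, and the steps for dimethylamino in place of nitro lie within the scatter, so this shows no gain from that change and no rule for other cores.

From the compounds shown here alone, it remains open whether the same agreement holds for other groups at these two places, such as a primary amine in place of dimethylamino or a carboxylic acid in place of cyano. A longer chain on the methylcarbamoyl nitrogen is likewise an open case.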